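The source may hold more compounds than are shown below. What is called first, only, known or untested is meant among the compounds shown, and "the series" means these compounds.

- compound 1 `COC(=O)c1ccc(CN2C(=O)C[C@@H](c3ccccc3Cl)[C@H]([N+](=O)[O-])[C@H]2c2ccc(O)cc2)cc1`: 3490 nM
- compound 2 `COc1cccc(CN2C(=O)C[C@@H](c3cc(OC)cc(OC)c3)[C@H]([N+](=O)[O-])[C@H]2c2ccc(O)cc2)c1`: 850 nM

Both values come from a functional assay on BV-2 cells (Mus musculus) for inhibition, read by ELISA, with stated times of 3 h and 12 h; on this read-out higher numbers stand for weaker inhibition and lower numbers for stronger inhibition. Of these two numbers, the lower belongs to compound 2 at 850 nM, and the gap up to compound 1 lies beyond the usual scatter. Compound 3 `COc1cc(OC)cc([C@@H]2CC(=O)N(Cc3ccc(OC)c(OC)c3)[C@H](c3ccc(O)cc3)[C@H]2[N+](=O)[O-])c1` is still unmeasured. It differs from compound 2 by methoxy in place of hydrogen on an aromatic carbon, which turns the 3-methoxybenzyl group into 3,4-dimethoxybenzyl. For the measured compounds named here, no measured pair isolates this change, and compounds 1 and 2 differ in more than one place, so the data give no direct guide to its size. In this assay, no shift beyond the scatter is expected, with a slight rise at most. The expected result is a 1.1-fold higher number from compound 2 to compound 3 (0.02 log units; within the scatter). For compound 3 the estimated value is 900 nM, with an expected range of 350 nM to 2300 nM.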

Compound 3, half-maximal inhibitory concentration: 210 nM
Estimate against measurement, compound 3: 4.3-fold (0.63 log units) above; the whole stated range lies above it.
By their numbers in this assay, from the lowest: compound 3; then compound 2; then compound 1.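

In this assay, for the compounds shown here, the only single-place step so far is a 4.0-fold lower number from compound 2 to compound 3 (0.61 log units; beyond the scatter), so methoxy in place of hydrogen, turning 3-methoxybenzyl into 3,4-dimethoxybenzyl, is not a silent change here. The read-out therefore responds to substitution at this aromatic carbon of the benzyl group, ortho to a methoxy group and para to a large group, a sensitivity that compounds 1 and 2 alone could not reveal. No measurement bearing on the origin of this step is available.

The compounds shown leave open whether methoxy itself is needed at this carbon, which a hydroxy group, a fluorine atom or an ethoxy group there would test. On these data alone, whether the step holds with other groups on the remaining aromatic rings of the shared core also remains open.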